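Swapping the methoxyphenyl of compound 3 for a halogenated ring

The compounds below may be only part of what the source reports. "The series", "measured", "known", "first", "only" and "open" are said of these compounds alone.

Measured so far, in a functional assay on HCT-116 cells (Homo sapiens) for inhibition, read by CCK-8 assay, with a stated time of 72 h; on this read-out higher numbers stand for weaker inhibition and lower numbers for stronger inhibition:
- compound 1 `Nc1ccccc1NC(=O)c1ccc(CNC(=O)c2n[nH]cc2NC(=O)c2ccccc2)cc1`: 1660 nM
- compound 2 `O=C(NO)c1ccc(CNC(=O)c2n[nH]cc2NC(=O)c2ccccc2F)cc1`: 2200 nM
- compound 3 `COc1ccccc1C(=O)Nc1c[nH]nc1C(=O)NCc1ccc(C(=O)Nc2ccccc2N)cc1`: 3680 nM

Compound 3 gives the highest number of the three, so it is the weakest inhibitor on this read-out; its gap to compound 2 lies within the scatter, while its gap to compound 1 lies beyond it.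

The unmeasured compound 4 `Nc1ccccc1NC(=O)c1ccc(CNC(=O)c2n[nH]cc2NC(=O)c2c(F)cccc2Cl)cc1` differs from compound 3 in one place: 2-chloro-6-fluorophenyl in place of 2-methoxyphenyl on a carbonyl carbon.

For the measured compounds named here, only one measured step touches this position. Going from compound 1 to compound 3, a methoxy replaced a hydrogen on that aromatic ring, and the number rose: a 2.2-fold higher number from compound 1 to compound 3 (0.35 log units; beyond the scatter). Compound 2 also carries a halogen on this ring, but it differs from compound 1 elsewhere as well, so its value can only be set beside the others: it sits between compound 1 and compound 3, within the scatter of both.

Removing the methoxy is therefore expected to bring the number back down somewhat, towards what compound 1 and compound 2 show, so the step from compound 3 to compound 4 is expected to be a 1.9-fold lower number from compound 3 to compound 4 (0.29 log units; within the scatter). Compound 4 is estimated at 1900 nM, with a range from 900 nM to 4200 nM.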

Compound 4, half-maximal inhibitory concentration: 700 nM
Compound 4: middle estimate off by 2.7-fold (0.43 log units), on the high side; the measured number lies below the stated range.
By their numbers in this assay, from the lowest: compound 4; then compounds 1, 2 and 3 (each within the scatter of the next, the first and the last beyond it).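

In this assay, for the compounds shown here, this position turns out to be more sensitive than the earlier compounds suggested: putting 2-chloro-6-fluorophenyl in place of 2-methoxyphenyl on the carbonyl carbon gives a 5.3-fold lower number from compound 3 to compound 4 (0.72 log units; beyond the scatter). The earlier step, a 2.2-fold higher number from compound 1 to compound 3 (0.35 log units; beyond the scatter), showed only that a substituent on this ring could weaken inhibition, but the new step, a 2.4-fold lower number from compound 1 to compound 4 (0.38 log units; beyond the scatter), shows that the unsubstituted phenyl of compound 1 is not the best ring here, since a substituted ring can also strengthen inhibition, so changes at this one position move the number in either direction. No measurement at hand explains why the 2-chloro-6-fluorophenyl ring behaves this way.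

As far as these compounds go, what a 2-chlorophenyl ring alone would give on this carbonyl carbon remains open, so the share of the chlorine and of the fluorine in the lower number cannot be told apart. Also open, from the compounds shown here alone, is whether this ring keeps its advantage when the hydroxamic acid end of compound 2 replaces the aminophenyl amide end, and how a ring bearing an amine or a carboxylic acid would fare at this position.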